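The source may hold more compounds than are shown below. What is called first, only, known or untested is meant among the compounds shown, and "the series" means these compounds.

Working notes on the series around the shared core of compound 1 `CC(C)(C)OC(=O)N1CCN(C(=S)SCc2cn(-c3ccccc3F)nn2)CC1`, with the variation confined to the substituent on the aromatic nitrogen. In a functional assay on ECa-109 cells (Homo sapiens) for inhibition, read by MTT assay, with a stated time of 72 h (a lower number here means a stronger inhibitor, a higher number a weaker inhibitor), compound 1 gives > 128000 nM, which is a limit of the assay rather than a number. Compound 2 `CC(C)(C)OC(=O)N1CCN(C(=S)SCc2cn(Cc3cc(=O)oc4cc(O)ccc34)nn2)CC1` gives > 128000 nM in this assay, again a limit. Compound 3 `Fc1ccccc1Cn1cc(CSC(=S)N2CCNCC2)nn1` gives > 128000 nM in this assay, also a limit. For the measured compounds named here, compound 1 therefore cannot be placed relative to the others: the three values shown all sit at the limit of > 128000 nM in this assay, at which 3 of the 3 values shown sit, and no step between measured compounds can be stated at all. Compound 4 `CC(C)(C)OC(=O)N1CCN(C(=S)SCc2cn(Cc3ccc(Cl)cc3)nn2)CC1` differs from compound 1 by 4-chlorobenzyl in place of 2-fluorophenyl on an aromatic nitrogen, the new group standing on an aromatic nitrogen of the five-membered aromatic ring with three nitrogen. Going by the values given here, with compound 1 itself at a limit, no direction can be taken from the measured data for this change; the step from compound 1 to compound 4 is expected to be a step that the limit leaves unreadable from compound 1 to compound 4, none beyond the scatter, because the limit of > 128000 nM in this assay, at which 3 of the 3 values shown sit, holds for every value so far. Compound 4 is estimated at 150000 nM in this assay, with a range from 30000 nM to 600000 nM, and the result is expected most likely to come back as a limit once more.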

Compound 4, half-maximal inhibitory concentration: > 128000 nM
Compound 4: a limit, no number; the forecaster's own chance of this, stated with the estimate: 80%; the middle value is on the limit's open side.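

No step can be read between compound 1 and compound 4, as each stands only at a limit in this assay. The compounds shown leave open whether any substituent on the aromatic nitrogen of the shared core gives a readable value, as all results so far coincide: the limit of > 128000 nM in this assay, at which 4 of the 4 values shown sit.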